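A Shorter Basic Tail on the Shared Core

The source may report more compounds than this note shows. Statements on the series, on what has been measured and on what is new or still open speak of the compounds shown alone.

Within the data shown here, compound 2 `O=C1c2c[n+]([O-])c3ccccc3c2C(=O)c2c1c1ccccc1n2CCCCN1CCNCC1` is the only member of this set with a number rather than a limit in a functional assay on SH-SY5Y cells (Homo sapiens) for cytotoxicity, read by MTT assay, with a stated time of 72 h; on this read-out lower numbers stand for stronger inhibition and higher numbers for weaker inhibition: compound 2 gives 1240 nM. Compound 1 `CC1(C)O[C@@H](CO)[C@H](Cn2cc(Cn3c4c(c5ccccc53)C(=O)c3c[n+]([O-])c5ccccc5c3C4=O)nn2)O1` is reported in this assay at the limit > 1000 nM. Compound 3 `CC1(C)OC[C@@H](Cn2cc(Cn3c4c(c5ccccc53)C(=O)c3c[n+]([O-])c5ccccc5c3C4=O)nn2)O1` is likewise reported at the limit > 1000 nM. The step that the two limits leave unreadable from compound 1 to compound 3 therefore cannot be read, and the limit of > 1000 nM in this assay, at which 2 of the 3 values shown sit, is all that separates those two compounds from compound 2. Compound 4 `O=C1c2c[n+]([O-])c3ccccc3c2C(=O)c2c1c1ccccc1n2CCN1CCCCC1` differs from compound 2 by piperidin-1-yl in place of 2-(piperazin-1-yl)ethyl on a saturated chain carbon, two bonds along the chain from an aromatic nitrogen. Among the measured compounds shown here, no measured step touches this change, so nothing beyond the scatter is expected in either direction in this assay. Compound 4 is therefore estimated to give 1200 nM, between 300 nM and 5000 nM, with the expected step of a 1.0-fold lower number from compound 2 to compound 4 (0.01 log units; within the scatter) lying within the scatter.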

Compound 4, half-maximal inhibitory concentration: 1860 nM
Estimate against measurement, compound 4: 1.6-fold (0.19 log units) below; the range from low to high includes it.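

Among these compounds, the first readable step in this assay is a 1.5-fold higher number from compound 2 to compound 4 (0.18 log units; within the scatter). At this place, on a saturated chain carbon two bonds along the chain from an aromatic nitrogen, piperidin-1-yl, with 0 hydrogen-bond donors, thus stands in for 2-(piperazin-1-yl)ethyl without a difference that can be told from the scatter.

As far as these compounds go, whether a morpholine, a carboxylic acid or a longer chain at this place would move the number beyond the scatter stays open. Compound 1 and compound 3 also remain outside any comparison with this pair, because each is reported only as a limit: the limit of > 1000 nM in this assay, at which 2 of the 4 values shown sit.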